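Shortening the side chain on the thiazolidine-type core

The compounds below may be only part of what the source reports. "The series", "measured", "known", "first", "only" and "open" are said of these compounds alone.

Measured compounds:
- compound 1, `C#CC(=O)N1C(C(CC)CCCC)SC[C@@H]1C(=O)OCC`: 1700 nM
- compound 2, `C#CC(=O)N1C(c2ccc(OC)cc2)SC[C@@H]1C(=O)OCC`: 1400 nM

Both compounds share a five-membered core carrying an ethynylcarbonyl group on the ring nitrogen and an ethoxycarbonyl group on one ring carbon, and were tested in a functional assay on Huh-7 cells (Homo sapiens) for inhibition, read by sulforhodamine B assay; a higher number here means a weaker inhibitor, a lower number a stronger inhibitor. Compound 1 gives 1700 nM, the higher of the two numbers, while compound 2 gives 1400 nM; the gap between them lies within the scatter of the assay, so no order can be read from it. Compound 1 carries a branched chain where compound 2 carries a methoxy-bearing aromatic ring, and these two quite different groups give almost the same number.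

Compound 3, `C#CC(=O)N1C(CCCC)SC[C@@H]1C(=O)OCC`, has not yet been measured. It differs from compound 1 in one place: butyl in place of 1-ethylpentyl on a saturated ring carbon. Since the swap of a branched chain for an aromatic ring left the number essentially unchanged, a shorter, straight chain at the same position is expected to matter little as well. The step from compound 1 to compound 3 is therefore expected to be a 1.2-fold higher number from compound 1 to compound 3 (0.07 log units; within the scatter), no larger than the scatter. Compound 3 is estimated at 2000 nM, within a range of 700 nM to 6000 nM.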

Compound 3, half-maximal inhibitory concentration: 500 nM
Beside the measured number, compound 3's estimate is 4.0-fold (0.60 log units) above it; measured number below the stated range.
By their numbers in this assay, from the lowest: compound 3; then compounds 2 and 1 (each within the scatter of the next).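

In this assay, butyl in place of 1-ethylpentyl on this saturated ring carbon gives a 3.4-fold lower number from compound 1 to compound 3 (0.53 log units; beyond the scatter), so this position does respond to the group it carries, which the earlier pair of compounds could not show. The change is also a clean one: both chains are made of carbon alone, with no ring and with 0 hydrogen-bond donors and 0 hydrogen-bond acceptors, so the difference between them lies in the chain itself, 7 heavy atoms leaving and 4 entering, with the branch gone. No measurement at hand explains how the chain change leads to the lower number.

This single step changes chain size and branching together, so the compounds shown leave open which of the two goes with the lower number; a straight heptyl chain or a branched chain such as isobutyl would separate them. They also leave open how far the trend runs, since a still shorter chain such as ethyl or methyl at this ring carbon could continue it, level off or reverse it.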